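From hexyl to benzyl: compound 2 to compound 3

The compounds below may be only part of what the source reports. "The series", "measured", "known", "first", "only" and "open" are said of these compounds alone.

Measured so far (a functional assay on NCI-H460 cells (Homo sapiens) for antiproliferative activity, read by MTT assay, with a stated time of 48 h; a lower number here means a stronger inhibitor, a higher number a weaker inhibitor)
- compound 1 (`CCCCC1(O)C(=O)Nc2ccc(Nc3ccc(C)cc3)cc21`) gives 31800 nM
- compound 2 (`CCCCCCC1(O)C(=O)Nc2ccc(Nc3ccc(C)cc3)cc21`) gives > 100000 nM as a limit, not a number

Compound 2 is known only as a limit (the limit of > 100000 nM in this assay, at which 1 of the 2 values shown sits). Compound 3 (`Cc1ccc(Nc2ccc3c(c2)C(O)(Cc2ccccc2)C(=O)N3)cc1`) differs from it by phenyl in place of pentyl on a saturated chain carbon bound to a saturated ring carbon, which puts phenyl in place of pentyl on a saturated chain carbon bound to a saturated ring carbon. Among the compounds with values here, the one measured step bearing on this is an at least 3.1-fold higher number from compound 1 to compound 2 (0.49 log units; beyond the scatter) and it concerns chain length only. Within the data shown here, no measured step covers a ring at this place, so compound 1 (31800 nM) serves as the nearest reference for the replacement of hexyl by benzyl. The expected change is an at least 2.8-fold lower number from compound 2 to compound 3 (0.45 log units; beyond the scatter) and it should point to a lower number, modest in size and uncertain. The estimate for compound 3 is 35000 nM (expected range 10000 nM to 100000 nM).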

Compound 3, half-maximal inhibitory concentration: 31600 nM
Compound 3: middle estimate off by 1.1-fold (0.04 log units), on the high side, within the range that was stated.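

In this assay, phenyl in place of pentyl on a saturated chain carbon bound to a saturated ring carbon gives an at least 3.1-fold lower number from compound 2 to compound 3 (0.50 log units; beyond the scatter), so the loss seen with hexyl does not extend to every group of this kind at this place. The reading for compound 2 is a limit, not a number, so this step has only a lower bound: the limit of > 100000 nM in this assay, at which 1 of the 3 values shown sits.

Phenyl in place of propyl gives a 1.0-fold lower number from compound 1 to compound 3 (0.00 log units; within the scatter), so the ring and the shorter chain read alike at this place.

Still open, from the compounds shown here alone, is whether a phenethyl group, a substituted benzyl group, or an amine or carboxylic acid on the chain would give a lower number in this assay. Also open is what the hydroxyl of the shared core contributes, as all the compounds shown carry it.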